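The source may hold more compounds than are shown below. What is called first, only, known or untested is meant among the compounds shown, and "the series" means these compounds.

Compound 1 `c1ccc(C2CCc3nc[nH]c3C2)cc1` gives 234 nM; 123 nM; 315 nM (3 entries); compound 2 `Fc1ccccc1C1Cc2nccn2C1` gives 42 nM; compound 3 `c1ccc2c(c1)CC(c1ncc[nH]1)C2` gives 1650 nM.

All three were read in a functional assay on CHO cells for agonist activity at Alpha-1A adrenergic receptor (Homo sapiens), read by FLIPR and calcium flux; on this read-out lower numbers stand for an effect already at smaller amounts and higher numbers for an effect only at larger amounts of compound. Among the single numbers, compound 2 gives the lowest; the nearest is compound 3, whose number lies above it by a gap beyond the scatter, while compound 1 has several entries, (the several entries of compound 1 in this assay, 234 nM; 123 nM; 315 nM (3 entries)), rather than one figure. Compound 4 `COc1ccccc1C1Cc2nccn2C1` differs from compound 2 in one place: methoxy in place of fluoro on an aromatic carbon. Among the compounds with values here, no step between measured compounds matches this change, so nothing measured sets its size. The step expected here, a 1.7-fold higher number from compound 2 to compound 4 (0.22 log units; within the scatter), is small, toward a slightly higher number if anything beyond the scatter. For compound 4 the value expected in this assay is 70 nM, within 20 nM to 250 nM.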

Compound 4, half-maximal effective concentration in the Alpha-1A adrenergic receptor assay: 22 nM
Compound 4: the middle estimate sits 3.2-fold (0.50 log units) above what was measured; the range from low to high includes it.
By their numbers in the Alpha-1A adrenergic receptor assay, from the lowest: compounds 4 and 2 (each within the scatter of the next); then compound 3.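

Methoxy in place of fluoro on an aromatic carbon, ortho to a group of 8 heavy atoms, gives the first step measured at this place: in the Alpha-1A adrenergic receptor assay it is a 1.9-fold lower number from compound 2 to compound 4 (0.28 log units; within the scatter) and the two compounds cannot be told apart. In a physicochemical assay for lipophilicity, at pH 7.4 (on this read-out higher numbers stand for higher lipophilicity and lower numbers for lower lipophilicity), the same change is a number 0.10 log units lower from compound 2 to compound 4 (within the scatter) and again separates nothing. In the physicochemical assay compound 2 gives 2 and compound 4 gives 1.9. The hydrogen-bond acceptor that methoxy brings thus shifts neither number beyond the scatter.

The data shown give no reason for this closeness. On these data alone, whether an amine, a carboxylic acid or a longer chain such as butoxy at this place would keep the number as close remains open.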